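The source may hold more compounds than are shown below. What is called first, only, known or untested is meant among the compounds shown, and "the series" means these compounds.

Compound 1 `CCCCCc1ccc(-c2cn(C[C@H](O)[C@H]3OC(=O)C(OCc4ccccc4)=C3OCc3ccccc3)nn2)cc1` stands as the stronger of the two compounds measured in a functional assay on SW-620 cells (Homo sapiens) for antiproliferative activity, read by MTT assay, with a stated time of 72 h; on this read-out higher numbers stand for weaker inhibition and lower numbers for stronger inhibition: compound 1 gives 12200 nM, whereas compound 2 `O=C1O/C(=C\Cn2cc(-c3cccc(O)c3)nn2)C(OCc2ccccc2)=C1OCc1ccccc1` gives 69800 nM, a gap beyond the usual scatter. Compound 3 `C[Si](C)(C)c1cn(C[C@H](O)[C@H]2OC(=O)C(OCc3ccccc3)=C2OCc2ccccc2)nn1` differs from compound 1 in one place: a group of 4 heavy atoms (3 carbon, 1 silicon; no ring) in place of a group of 11 heavy atoms (11 carbon; one six-membered aromatic ring of carbon only), on an aromatic carbon. Among the measured compounds shown here, no step between measured compounds covers a change of this kind, so the expectation rests on the two values alone. The step from compound 1 to compound 3 is expected to run toward weaker inhibition and beyond the scatter, a 2.5-fold higher number from compound 1 to compound 3 (0.39 log units; beyond the scatter). Compound 3 is therefore estimated at 30000 nM, within a range of 8000 nM to 120000 nM.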

Compound 3, half-maximal inhibitory concentration: 56000 nM
Beside the measured number, compound 3's estimate is 1.9-fold (0.27 log units) below it; the range from low to high includes it.
By their numbers in this assay, from the lowest: compound 1; then compounds 3 and 2 (each within the scatter of the next).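

At this aromatic carbon of the five-membered aromatic ring with 3 nitrogen, exchanging 4-pentylphenyl for the silicon-bearing group of 4 heavy atoms brings a 4.6-fold higher number from compound 1 to compound 3 (0.66 log units; beyond the scatter). The group at this position therefore matters, and in this single pair the larger group with the aromatic ring goes with the stronger inhibition. No measurement available here bears on why this step occurs. The compounds shown leave open whether the ring or the pentyl chain of 4-pentylphenyl carries the difference, and how an unsubstituted phenyl or a tert-butyl group at this carbon would compare.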